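Cytotoxicity on macrophages: amide in place of ethyl

The source may hold more compounds than are shown below. What is called first, only, known or untested is meant among the compounds shown, and "the series" means these compounds.

Measured so far:
compound 1, `CCCCc1cc2c(=O)c(CC)c[nH]c2cc1OCCOc1ccccc1`, 360 nM
compound 2, `CCOc1ccc2[nH]cc(C(=O)OC)c(=O)c2c1`, > 20000 nM
compound 3, `CCc1cc2c(=O)c(C(=O)OC)c[nH]c2cc1OCCOc1ccccc1`, > 20000 nM

Among the measured compounds shown here, in an ADME assay on J774 cells (Mus musculus) for cytotoxicity (on this read-out higher numbers stand for an effect only at larger amounts of compound and lower numbers for an effect already at smaller amounts), compound 1 gives 360 nM and is the only compound in this set with a numeric value. Compound 2 gives > 20000 nM, which is a limit of this assay and not a number. Compound 3 likewise gives > 20000 nM, again a limit. Two of the three results therefore sit at the limit of > 20000 nM in this assay, at which 2 of the 3 values shown sit, and only compound 1 shows an effect within the measured range.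

Compound 4, `CCCCc1cc2c(=O)c(C(=O)NC(C)C)c[nH]c2cc1OCCOc1ccccc1`, is not yet measured in this assay. The change from compound 1 to compound 4 is isopropylcarbamoyl in place of ethyl on an aromatic carbon. Both compounds whose values sit at the limit carry a carbonyl-bearing group in this position rather than the ethyl of compound 1, although neither differs from compound 1 in that place alone, so no single step can be read from them. The expectation is a step of a 28-fold higher number from compound 1 to compound 4 (1.44 log units; beyond the scatter) from compound 1 to compound 4, well beyond the scatter, towards an effect only at larger amounts. For compound 4 the estimate is 10000 nM, between 2000 nM and 40000 nM, with a fair chance that this assay reports only a limit.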

Compound 4, half-maximal effective concentration: > 20000 nM
Compound 4: no number, only a limit; the forecaster's own chance of this, stated with the estimate: 55%; at least 2.0-fold (0.30 log units) between middle value and limit.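

In this assay, among the compounds shown here, isopropylcarbamoyl in place of ethyl on an aromatic carbon gives an at least 55-fold higher number from compound 1 to compound 4 (1.74 log units; beyond the scatter), the only step in this set that can be read at a single place. Compound 4 gives > 20000 nM, which is a limit and not a number. With the rest of compound 1 kept, this one place is enough to take the read-out out of the measured range, something compound 2 and compound 3 could not show, as each differs from compound 1 in more than this place, and the set now stands as follows: the limit of > 20000 nM in this assay, at which 3 of the 4 values shown sit.

As far as these compounds go, how far the value of compound 4 lies beyond the limit stays open, as does whether the larger size of the entering group, its carbonyl or the amide hydrogen matters most in this assay. Also open, from the compounds shown here alone, is whether a carboxylic acid, a propyl chain, an aminomethyl group or a smaller amide without the isopropyl part at this position would keep an effect within the measured range.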